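Trimming sec-butyl to isopropyl on an inactive hydantoin

A few compounds are considered here, and "the series" means these few. Any claim that something is new, unique, unknown or untested is made for them only; others in the source may bear on it.

Measured compounds:
compound 1 `CCC(C)C1NC(=O)N(C2CCCCC2)C1=O` — in a functional assay on SW-620 cells (Homo sapiens) for inhibition (on this read-out lower numbers stand for stronger inhibition and higher numbers for weaker inhibition), compound 1 shows only a limit, > 100000 nM
compound 2 `CC(C)C(NC(=O)NO)C(=O)NC1CCCC1` — in this assay compound 2 likewise shows only a limit, > 100000 nM

Compound 1 therefore does not stand at any number in this assay; its value is a limit, and the same holds for compound 2, so that the limit of > 100000 nM in this assay, at which 2 of the 2 values shown sit, is all the two results have to offer. Among the compounds with values here, no step between measured compounds can be drawn from them.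

Compound 3 `CC(C)C1NC(=O)N(C2CCCCC2)C1=O` differs from compound 1 in one place: hydrogen in place of methyl on a saturated chain carbon, two bonds along the chain from a saturated ring carbon, which, cut one bond further out, reads sec-butyl to isopropyl. Since the starting point in this assay is only a limit, the account can follow the change in structure but not a measured shift in potency.

The step implied by the estimate, a step that the limit leaves unreadable from compound 1 to compound 3, is expected to stay within the scatter, with no direction beyond it. Compound 3 is accordingly expected to give about 150000 nM in this assay, with a range from 50000 nM to 500000 nM, and most likely again only a limit rather than a number.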

Compound 3, half-maximal inhibitory concentration: > 100000 nM
Compound 3: only a limit was reported (the forecaster's own chance of this, stated with the estimate: 85%); the middle value is on the limit's open side.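

Compound 3, like compound 1, gives only a limit in this assay, so no step from compound 1 to compound 3 can be read, and the comparison ends at: the limit of > 100000 nM in this assay, at which 3 of the 3 values shown sit.

The compounds shown leave open whether going from sec-butyl to isopropyl alters inhibition at all, and which structural feature would bring a measurable value in this assay.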